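The compounds below may be only part of what the source reports. "The series", "measured", "known", "first", "only" and "open" are said of these compounds alone.

Working notes on the series. Compound 1, `CCNC(=O)NCC1CCc2c(cccc2OC)N1`, in a functional assay on CHO cells with melatonin receptor type 1A (Homo sapiens) as the target, read by GTPgammaS binding, with a stated time of 1 h (a higher number here means that more compound is needed for the effect, a lower number that less compound is needed), stands at "not determined" (no result reported), with no result reported. Within the data shown here, compound 2, `CCNC(=O)NCC1CCc2ccccc2N1`, is therefore the only member with a number: in this assay compound 2 gives 2420 nM, which is the sole reference point here, so no step between measured compounds can be stated and no pattern can be drawn from the pair.

The next compound, compound 3, `CCNC(=S)NCC1CCc2ccccc2N1`, differs from compound 2 in one place: a group of 5 heavy atoms (3 carbon, 1 nitrogen, 1 sulfur; no ring) in place of a group of 5 heavy atoms (3 carbon, 1 nitrogen, 1 oxygen; no ring), on an amine nitrogen. Among the measured compounds shown here, no measured step of this kind exists, so the expectation rests on the single value of compound 2 alone. With one ethylcarbamoyl-sized group swapped for a group of the same size and the same count of donors and acceptors, the step from compound 2 to compound 3 is expected to stay within the usual scatter, that is a 1.2-fold lower number from compound 2 to compound 3 (0.08 log units; within the scatter). For compound 3 in this assay the estimate is 2000 nM, with a range from 600 nM to 7000 nM.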

Compound 3, half-maximal effective concentration: 2660 nM
Beside the measured number, compound 3's estimate is 1.3-fold (0.12 log units) below it; the measured number falls inside the stated range.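

In this assay, among these compounds, the exchange of the ethylcarbamoyl group on the amine nitrogen for its sulfur-bearing counterpart gives a 1.1-fold higher number from compound 2 to compound 3 (0.04 log units; within the scatter), the first measured step. At this place, compound 2 and compound 3 cannot be told apart in this assay, so the oxygen-to-sulfur exchange at this group leaves no readable mark on the number. Nothing available on these compounds accounts for this result.

This single step does not show whether other replacements on the same nitrogen, such as a guanidine, an acetyl group or a longer chain like propyl in place of the ethyl, would stay equally close to compound 2. From the compounds shown here alone, no step can be read for the methoxy group of compound 1, so substitution on the shared core remains open.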